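Working notes on efficacy across three analogues and one pending

The source may report more compounds than this note shows. Statements on the series, on what has been measured and on what is new or still open speak of the compounds shown alone.

Values in an assay on isolated protein for agonist activity at Bile acid receptor (Homo sapiens), read by AlphaScreen, with a stated time of 30 min (a lower number here means a smaller maximal response, a higher number a larger maximal response), so far:
- compound 1 `Cc1ccccc1-n1nc(C)c2c1NC(=O)[C@H](C)S[C@@H]2c1ccc(-c2cc3ccccc3o2)cc1`: 17%
- compound 2 `Cc1ccccc1-n1nc(C)c2c1NC(=O)[C@H](C)S[C@@H]2c1ccc(-c2ccsc2)cc1`: 68%
- compound 3 `COc1cc([C@H]2S[C@@H](C)C(=O)Nc3c2c(C)nn3-c2ccccc2C)ccc1Oc1ccccc1`: 130%

Compound 3 gives the highest maximal response of the three; the gaps to compound 2 and to compound 1 both lie beyond the scatter. Compound 4 `Cc1ccccc1-n1nc(C)c2c1NC(=O)[C@H](C)S[C@@H]2c1ccc(Oc2ccccc2)cc1` is the next analogue; it differs from compound 3 by hydrogen in place of methoxy on an aromatic carbon. Within the data shown here, the only measured single-site step, a number 51 percentage points higher from compound 1 to compound 2 (beyond the scatter), concerns the aryl substituent on the opposite side of the core, not the ring that carries the phenoxy group, so no measured step bears directly on removing the methoxy. The expectation is therefore a modest downward step, a number 30 percentage points lower from compound 3 to compound 4 (beyond the scatter), with wide uncertainty. Compound 4 is estimated at 100%, in the range 50% to 140%.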

Compound 4, largest response reached (reported as efficacy), in percent of the reference or control that the assay uses: 118%
The estimate for compound 4 lay 18 percentage points below the measured number; measured number inside the range.
By their numbers in this assay, from the lowest: compound 1; then compound 2; then compound 4; then compound 3.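

Hydrogen in place of methoxy gives a number 12 percentage points lower from compound 3 to compound 4 (beyond the scatter), a real but modest loss, so compound 4 at 118% keeps most of the maximal response without that group. Phenoxy in place of thiophen-3-yl gives a number 50 percentage points higher from compound 2 to compound 4 (beyond the scatter), and phenoxy in place of 1-benzofuran-2-yl gives a number 101 percentage points higher from compound 1 to compound 4 (beyond the scatter), both far larger than the methoxy step. Nothing measured here offers a reason for these steps.

Still open, going by these compounds, is whether an amine or a carboxylic acid on that aromatic carbon would keep the response. Also open, on these data alone, is whether a benzyloxy group could stand in for phenoxy.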